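Ethyl ester of compound 3: what to expect

The source may hold more compounds than are shown below. What is called first, only, known or untested is meant among the compounds shown, and "the series" means these compounds.

Of the compounds shown here, three sharing one core have been measured in an assay on isolated protein for inhibition of Dipeptidase 1 (Sus scrofa); a lower number here means a stronger inhibitor, a higher number a weaker inhibitor. Compound 1 `CCCCc1nn(-c2cccc(Cl)c2)c(C(=O)O)c1Cc1ccc(-c2ccccc2-c2nn[nH]n2)cc1` gives 425000 nM. Compound 2 `CCCCc1nn(-c2ccccc2Cl)c(C(=O)OCC)c1Cc1ccc(-c2ccccc2-c2nn[nH]n2)cc1`, which carries a chloro on a different aromatic carbon and an ethoxycarbonyl group instead of the carboxy group, gives 250000 nM. Compound 3 `CCCCc1nn(-c2ccccc2)c(C(=O)O)c1Cc1ccc(-c2ccccc2-c2nn[nH]n2)cc1`, the parent with a plain phenyl ring and the carboxy group, gives 590000 nM, the highest of the three numbers. For the measured compounds named here, the only single-point step among them, a 1.4-fold higher number from compound 1 to compound 3 (0.14 log units; within the scatter), lies within the scatter, so the chloro makes no clear difference.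

Compound 4 `CCCCc1nn(-c2ccccc2)c(C(=O)OCC)c1Cc1ccc(-c2ccccc2-c2nn[nH]n2)cc1` is the next step from compound 3: ethyl in place of hydrogen on an oxygen next to a carbonyl group. Going by the values given here, no measured pair differs in that one place alone. Among the compounds with values here, the only hint is that compound 2, which also carries the ethoxycarbonyl group, has the lowest of the three numbers, yet it differs from compound 3 in two places, so its value cannot be split between the two changes. On that thin basis the step from compound 3 to compound 4 is expected to be small, a 1.8-fold lower number from compound 3 to compound 4 (0.27 log units; within the scatter), leaning toward a lower number, and compound 4 is estimated at 320000 nM, with a range from 110000 nM to 950000 nM.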

Compound 4, inhibition constant: 250000 nM
Compound 4: the middle estimate sits 1.3-fold (0.11 log units) above what was measured; measured number inside the range.
By their numbers in this assay, from the lowest: compounds 2, 4, 1 and 3 (each within the scatter of the next, the first and the last beyond it).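

For the compounds shown here, compound 3 and compound 4 form the first measured pair that isolates the change from carboxy to ethoxycarbonyl, and in this assay the step is a 2.4-fold lower number from compound 3 to compound 4 (0.37 log units; beyond the scatter) and so a modest but readable move on this oxygen next to a carbonyl group. Compound 4 also gives a second reading of hydrogen in place of chloro on an aromatic carbon, no change at the digits printed from compound 2 to compound 4 (within the scatter) and so no clear effect of the chloro in the ethoxycarbonyl series. That result agrees with the reading from the carboxy series: the same change on two cores in this assay, a 1.4-fold higher number (0.14 log units; within the scatter) from compound 1 to compound 3 and no change at the digits printed (within the scatter) from compound 2 to compound 4, 1.4-fold (0.14 log units) apart, within the scatter of two such steps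

As far as these compounds go, the ethyl step has been read on one pair only, as compound 1 and compound 2 carry their chloro on different aromatic carbons and differ in two places, so it remains open whether the step would be the same with a chloro present. Also open, from the compounds shown here alone, is how the number would respond to a methyl or a longer chain on this oxygen, or to an amine in place of the ethoxy group.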